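Compound 2 and a sulfonyl replacement

The compounds below may be only part of what the source reports. "The series", "measured", "known", "first", "only" and "open" are said of these compounds alone.

Compound 1 `O=S(=O)(Nc1ccc(-c2nc3cc(NS(=O)(=O)c4cccc(C(F)(F)F)c4)ccc3o2)cc1)c1cccc(C(F)(F)F)c1`: 19000 nM
Compound 2 `COc1ccc(S(=O)(=O)Nc2ccc3oc(-c4ccc(NC(=O)c5cccc(C)c5[N+](=O)[O-])cc4)nc3c2)cc1`: 2300 nM

In a functional assay on HT-29 cells (Homo sapiens) for cytotoxicity, read by resazurin assay, with a stated time of 48 h (on this read-out lower numbers stand for an effect already at smaller amounts and higher numbers for an effect only at larger amounts of compound), compound 2 gives 2300 nM, the lower of the two numbers, and its gap to compound 1 lies beyond the scatter. Compound 3 `COc1ccc(S(=O)(=O)Nc2ccc3oc(-c4ccc(NS(=O)(=O)c5cc(Br)ccc5OC)cc4)nc3c2)cc1` differs from compound 2 in one place: (5-bromo-2-methoxyphenyl)sulfonyl in place of (3-methyl-2-nitrophenyl)carbonyl on a nitrogen on an aromatic ring. A (5-bromo-2-methoxyphenyl)sulfonyl replaces (3-methyl-2-nitrophenyl)carbonyl on a nitrogen on an aromatic ring. Compound 1 also carries a sulfonyl group on such a nitrogen and gives 19000 nM, so a higher number is expected, although two compounds are thin evidence. The expected step is a 2.6-fold higher number from compound 2 to compound 3 (0.42 log units; beyond the scatter), a move towards a weaker effect in this assay. For compound 3 the estimated value is 6000 nM, with an expected range from 1500 nM to 25000 nM.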

Compound 3, half-maximal effective concentration: 14000 nM
Compound 3: middle estimate off by 2.3-fold (0.37 log units), on the low side, within the range that was stated.
By their numbers in this assay, from the lowest: compound 2; then compounds 3 and 1 (each within the scatter of the next).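

In this assay, the group on this nitrogen on an aromatic ring matters: (5-bromo-2-methoxyphenyl)sulfonyl in place of (3-methyl-2-nitrophenyl)carbonyl gives a 6.1-fold higher number from compound 2 to compound 3 (0.78 log units; beyond the scatter), a modest move towards a weaker effect. The two groups have the same counts of heavy atoms, hydrogen-bond donors and acceptors, and these counts do not tell them apart. Nothing measured here explains the step.

The swap of carbonyl for sulfonyl and the change of ring substituents arrive together, and their shares cannot be told apart. From the compounds shown here alone, how a simple acetyl on this nitrogen would read remains open.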